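Cyclohexyl to 3-methylphenyl at the limit of stability

This account rests on a few compounds, and the source may have more. Where it says the series, first, only, none or still open, it means among the compounds named here.

Compound 1 (`COc1ccc(-c2c(C)nc3c(N4CC[C@@H](NC(C)=O)C4)cc(C)nn23)cc1OC`) gives > 95% in an ADME assay on microsomes from liver (Mus musculus) for metabolic stability, read by LC-MS, with NADPH named in the record, with a stated time of 60 min, tested at 1 uM, in the absence of a further agent (on this read-out higher numbers stand for a more stable compound and lower numbers for a less stable compound), as a limit of the assay. Compound 2 (`COc1ccc(-c2c(C)nc3c(N4CC[C@@H](NC(=O)OC5CCCCC5)C4)cc(C)nn23)cc1OC`) gives > 95% in this assay as a limit too. The evidence so far is the limit of > 95% in this assay, at which 2 of the 2 values shown sit, and nothing finer. Within the data shown here, the one measured step is a step that the two limits leave unreadable from compound 1 to compound 2 and offers no size to carry forward. Compound 3 (`COc1ccc(-c2c(C)nc3c(N4CC[C@@H](NC(=O)Oc5cccc(C)c5)C4)cc(C)nn23)cc1OC`) differs from compound 2 by 3-methylphenyl in place of cyclohexyl on an oxygen next to a carbonyl group and has 3-methylphenyl in place of cyclohexyl on an oxygen next to a carbonyl group. The expectation rests on compound 2 with > 95% as its limit, and it points to a modest fall or to none beyond the scatter. The estimated move is a number at least 7 percentage points lower from compound 2 to compound 3 (that floor lies within the scatter) in this assay and may stay within the scatter. For compound 3 the estimated value is 88% with an expected range from 65% to 100% in this assay and the reading may again be only a limit.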

Compound 3, percent of the compound remaining: > 95%
Compound 3: a limit, no number (the forecaster's own chance of this, stated with the estimate: 40%); at least 7 percentage points between middle value and limit.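

Among these compounds, no step among compound 1, compound 2 and compound 3 can be read in this assay, as all three readings are limits of the assay and give no size. The compounds shown leave open whether methyl, cyclohexyloxy and 3-methylphenoxy on a carbonyl carbon differ at all in stability, since the evidence remains a single reading: the limit of > 95% in this assay, at which 3 of the 3 values shown sit.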